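A few compounds are considered here, and "the series" means these few. Any claim that something is new, unique, unknown or untested is made for them only; others in the source may bear on it.

Measured compounds:
- compound 1, `CCn1c(C(=O)NCCC(=O)OC)ccc1C(CC)(CC)c1ccc(OCS(=O)(=O)c2ccccc2)c(C)c1`, in a functional assay on PC-3 cells (Homo sapiens) for antiproliferative activity, read by MTT assay, with a stated time of 24 h (on this read-out higher numbers stand for weaker inhibition and lower numbers for stronger inhibition), compound 1 gives 40400 nM
- compound 2, `CCn1c(C(=O)N[C@H](C)CO)ccc1C(CC)(CC)c1ccc(OCS(=O)(=O)c2ccccc2)c(C)c1`, in this assay compound 2 gives 7790 nM

Among the measured compounds shown here, compound 2 stands as the lower of the two numbers, and the only step measured so far, a 5.2-fold lower number from compound 1 to compound 2 (0.71 log units; beyond the scatter), was the one that brought it there; it swapped one chain on the amide-type nitrogen for another, with the rest of the shared core untouched.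

Compound 3, `CCn1c(C(=O)NCC(=O)O)ccc1C(CC)(CC)c1ccc(OCS(=O)(=O)c2ccccc2)c(C)c1`, has not yet been measured. It differs from compound 2 at the same place: carboxymethyl in place of 1-(hydroxymethyl)ethyl on an amide-type nitrogen. For the measured compounds named here, only the step from compound 1 to compound 2 bears on this position, and it was modest in size. Going by the values given here, compound 3 shares with compound 1 a chain that carries a carbonyl and, like compound 2, a chain with one hydrogen-bond donor, so the one known step pulls in no clear direction. The expected change is therefore small, perhaps none beyond the scatter, with a lean toward a somewhat higher number: the step from compound 2 to compound 3 is estimated at a 1.5-fold higher number from compound 2 to compound 3 (0.19 log units; within the scatter). Compound 3 is expected to give about 12000 nM, within a range of 4000 nM to 40000 nM.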

Compound 3, half-maximal inhibitory concentration: 30100 nM
The estimate for compound 3 lay 2.5-fold (0.40 log units) below the measured number; measured number inside the range.
By their numbers in this assay, from the lowest: compound 2; then compounds 3 and 1 (each within the scatter of the next).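

Swapping 1-(hydroxymethyl)ethyl for carboxymethyl on the amide-type nitrogen gave a 3.9-fold higher number from compound 2 to compound 3 (0.59 log units; beyond the scatter) and shows that this position responds even when the entering and leaving chains match in their counts of heavy atoms, hydrogen-bond donors and hydrogen-bond acceptors. The other new step, a 1.3-fold lower number from compound 1 to compound 3 (0.13 log units; within the scatter), lies within the scatter, so the carboxy end of compound 3 and the (methoxycarbonyl)methyl end of compound 1 cannot be told apart on this read-out, although the two chains also differ in length. Among these three chains, only the 1-(hydroxymethyl)ethyl of compound 2 stands apart from the other two by more than the scatter, and no measurement shown here gives an explanation for that.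

Going by these compounds, the hydroxyl group, the branching methyl and the defined stereocentre all leave together in the step to compound 3, so the contribution of each remains unknown. An unbranched 2-hydroxyethyl chain, the opposite stereocentre in the 1-(hydroxymethyl)ethyl chain, or a chain ending in an amine would be needed to separate these features and widen the picture at this position.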